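A few compounds are considered here, and "the series" means these few. Any claim that something is new, unique, unknown or untested is made for them only; others in the source may bear on it.

Two styryl aryl ethers with a four-carbon chain to a basic nitrogen have been run in a functional assay on the whole organism with Mus musculus as the target, in the maximal electroshock model, at a dose of 50 mg/kg by the oral route; a higher number here means more inhibition at the dose given (going by the name of the read-out), a lower number less inhibition. Compound 1, `CN(C)CCCCOc1ccccc1/C=C/c1cccc(Cl)c1`, gives 14.3%, while compound 2, `CCCN(CCC)CCCCOc1ccccc1/C=C/c1ccccc1`, gives 0%, the lower of the two numbers, a gap beyond the scatter. Compound 3, `C(=C/c1ccccc1OCCCCN1CCNCC1)\c1ccccc1`, is the next analogue: piperazin-1-yl in place of dipropylamino on a saturated chain carbon, four bonds along the chain from an oxygen on an aromatic ring. Within the data shown here, with no comparable pair measured, the expected step of a number 10 percentage points higher from compound 2 to compound 3 (within the scatter) is small and upward, not clearly beyond the scatter. Compound 3 is therefore estimated at 10%, in the range 0% to 35%.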

Compound 3, a percentage reported as inhibition, in the whole organism at one dose (the size of the read-out at that dose, not a potency): 0%
The estimate for compound 3 lay 10 percentage points above the measured number; measured number inside the range.
By their numbers in this assay, from the lowest: compounds 2 and 3 (each within the scatter of the next); then compound 1.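

The change to piperazin-1-yl in place of dipropylamino on a saturated chain carbon, four bonds along the chain from an oxygen on an aromatic ring, gives no change at the digits printed from compound 2 to compound 3 (within the scatter) in this assay at this chain end. Both amines read at the bottom of the scale here, so this pair cannot rank them. Nothing available explains the result.

Open, from the compounds shown here alone, is whether morpholin-4-yl or 4-methylpiperazin-1-yl at this chain end would read differently. Compound 1 differs from both others in more than one place, so the source of its higher number cannot be read.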